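The source may hold more compounds than are shown below. What is called first, only, known or untested is meant among the compounds shown, and "the series" means these compounds.

Measured so far:
- compound 1, `COc1cc(Cl)cc(-c2nn(-c3cccc(NC(=O)Nc4ccc(Cl)c(C(F)(F)F)c4)c3)cc2-c2ccncc2)c1`, in a functional assay on SW-620 cells (Homo sapiens) for inhibition, read by sulforhodamine B assay, with a stated time of 48 h, tested at 10 uM (on this read-out lower numbers stand for a stronger effect and higher numbers for a weaker effect at the one concentration tested), gives 12.7%
- compound 2, `COc1cc(Cl)cc(-c2nn(-c3cccc(NC(=O)Nc4cccc(C(F)(F)F)c4)c3)cc2-c2ccncc2)c1`, in this assay gives 11.2%

Compound 2 stands at the lower of the two numbers in this assay; its nearest neighbour is compound 1, and the step of a number 1.5 percentage points lower from compound 1 to compound 2 (within the scatter) is within the scatter, so the two compounds cannot be told apart on this read-out.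

Compound 3, `COc1cc(Cl)cc(-c2nn(-c3cccc(NC(=O)c4cccc(C(F)(F)F)c4)c3)cc2-c2ccncc2)c1`, is the next member and is not yet measured. It differs from compound 2 in one place: 3-(trifluoromethyl)phenyl in place of (3-(trifluoromethyl)phenyl)amino on a carbonyl carbon.

Among the compounds with values here, no measured step bears on this change. Within the data shown here, the only step in hand, a number 1.5 percentage points lower from compound 1 to compound 2 (within the scatter), concerns a different position and was within the scatter, so it gives no guidance on what replacing the amino-bearing group with the plain aryl group on the carbonyl carbon will do in this assay. The expectation therefore rests on compound 2 alone, with a wide range to allow for either direction; the expected step is a number 6.8 percentage points higher from compound 2 to compound 3 (within the scatter). Compound 3 is estimated at 18%, between 5% and 45%.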

Compound 3, a percentage reported as activity, at one concentration (the size of the read-out at that concentration, not a potency): 77%
The estimate for compound 3 lay 59 percentage points below the measured number; measured number outside the range, above it.
By their numbers in this assay, from the lowest: compounds 2 and 1 (each within the scatter of the next); then compound 3.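

In this assay, the group on the carbonyl carbon matters in a way the chloro change did not: replacing (3-(trifluoromethyl)phenyl)amino with 3-(trifluoromethyl)phenyl gives a number 65.8 percentage points higher from compound 2 to compound 3 (beyond the scatter). Replacing the chloro-bearing (4-chloro-3-(trifluoromethyl)phenyl)amino group with the same aryl group gives a number 64.3 percentage points higher from compound 1 to compound 3 (beyond the scatter), so both amino-bearing compounds show a much stronger effect at the one concentration tested than the plain aryl compound. Nothing at hand accounts for the size of this loss.

Going by these compounds, it remains open whether the amino nitrogen itself is what counts, and a methylene group, an oxygen or an N-methyl amino group in its place on the carbonyl carbon would test this. On these data alone, it also remains open whether a chloro group on the aryl ring would make any difference once the amino nitrogen is gone.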